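The compounds below may be only part of what the source reports. "The series", "measured", "known", "first", "only" and "open" are said of these compounds alone.

Compound 1 `CC(C)=CCC/C(C)=C/CC/C(C)=C/CC/C(C)=C/C[n+]1cn(C(c2ccccc2)c2ccccc2)c2nc[nH]/c(=N\OCc3ccccc3)c21`: 4240 nM
Compound 2 `CO/N=c1\[nH]cnc2c1[n+](C/C=C(\C)CCCC(C)CCCC(C)CCCC(C)C)cn2C`: 5400 nM

In a functional assay on U-937/GTB cells (Homo sapiens) for cytotoxicity (a lower number here means a stronger inhibitor, a higher number a weaker inhibitor), compound 2 stands at 5400 nM, within the usual scatter of compound 1 at 4240 nM. Compound 3 `C/C(=C\C[n+]1cn(C)c2nc[nH]/c(=N\OCc3ccccc3)c21)CCCC(C)CCCC(C)CCCC(C)C` is compound 2 with one change: phenyl in place of hydrogen on a saturated chain carbon bound to an oxygen, so that methoxy becomes benzyloxy. Among the measured compounds shown here, no measured pair isolates this change. Compound 1 also bears benzyloxy and gives 4240 nM, though it differs from compound 3 elsewhere. A step beyond the scatter in this assay is therefore not expected, in either direction. The estimated change is a 1.5-fold lower number from compound 2 to compound 3 (0.19 log units; within the scatter), which would stay within the scatter. For compound 3 the expected value is 3500 nM, with an estimated range of 1500 nM to 8000 nM.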

Compound 3, half-maximal inhibitory concentration: 10800 nM
For compound 3 the middle estimate is 3.1-fold (0.49 log units) below the measured one; the whole stated range lies below it.
By their numbers in this assay, from the lowest: compounds 1, 2 and 3 (each within the scatter of the next, the first and the last beyond it).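

In this assay, among the compounds shown here, the first step that isolates this position, methoxy to benzyloxy, gives a 2.0-fold higher number from compound 2 to compound 3 (0.30 log units; within the scatter). Phenyl, with its 6 heavy atoms, can therefore stand on a saturated chain carbon bound to an oxygen without a step beyond the scatter, so in this pair the assay separates neither group from the other. Nothing at hand accounts for this result, and no measurement on these compounds bears on it.

The compounds shown leave open how an amine or a carboxylic acid would read on that same carbon. They also leave open whether methoxy to benzyloxy would give a similar step with the chain and the other substituent of compound 1, which differs from compound 3 in more than one place.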